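Amide in place of alkyl chain on the piperidine series

The source may hold more compounds than are shown below. What is called first, only, known or untested is meant among the compounds shown, and "the series" means these compounds.

Three compounds share a core that carries a cyclopropyl-bearing acid chain. Compound 1 `COc1ccc(CCCC(C)(C)C)c(-c2ccc(COc3cccc(C(CC(=O)O)C4CC4)c3)cc2)c1` gives 410 nM in a functional assay on cells for agonist activity at Free fatty acid receptor 1 (Homo sapiens), read by FLIPR and calcium flux, with a stated time of 60 min; on this read-out lower numbers stand for an effect already at smaller amounts and higher numbers for an effect only at larger amounts of compound. Compound 2 `COc1ccc(F)c(N2CCC(COc3cccc(C(CC(=O)O)C4CC4)c3)CC2)c1` gives 670 nM in this assay. Compound 3 `COc1ccc(CCC(C)(C)C)c(N2CCC(COc3cccc(C(CC(=O)O)C4CC4)c3)CC2)c1` gives 34 nM, the lowest of the three numbers, with compound 1 nearest and compound 2 furthest from it. Among the compounds with values here, the step from compound 2 to compound 3 a 20-fold lower number from compound 2 to compound 3 (1.29 log units; beyond the scatter) is the only measured step, and it shows that the group at this position matters greatly. Compound 4 `COc1ccc(C(=O)N(C)CC(C)(C)C)c(N2CCC(COc3cccc(C(CC(=O)O)C4CC4)c3)CC2)c1` differs from compound 3 by methyl(neopentyl)carbamoyl in place of 3,3-dimethylbutyl on an aromatic carbon. The measured step removed the 3,3-dimethylbutyl altogether, whereas here a group with a related branched carbon skeleton and a carbonyl is put in its place. A higher number than for compound 3 is therefore expected for compound 4, but a smaller rise than from compound 2 to compound 3, giving an expected step of a 3.5-fold higher number from compound 3 to compound 4 (0.55 log units; beyond the scatter). Compound 4 is estimated at 120 nM, within a range from 35 nM to 450 nM.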

Compound 4, half-maximal effective concentration: 100 nM
Estimate against measurement, compound 4: 1.2-fold (0.08 log units) above; measured number inside the range.
By their numbers in this assay, from the lowest: compound 3; then compound 4; then compounds 1 and 2 (each within the scatter of the next).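

In this assay, methyl(neopentyl)carbamoyl in place of 3,3-dimethylbutyl gives a 2.9-fold higher number from compound 3 to compound 4 (0.47 log units; beyond the scatter) as a modest step, so the all-carbon chain remains the better of these two groups. Against fluoro, the same amide still gives a 6.7-fold lower number from compound 2 to compound 4 (0.83 log units; beyond the scatter) as its step, which shows that a large gain at this position does not require an all-carbon chain, since a group holding a carbonyl and a nitrogen also delivers much of it. No supporting data explain why the amide falls short of the chain.

On these data alone, how a ketone or a sulfonamide would compare here remains open, as does the same amide with an amide hydrogen in place of its methyl. Also open, as far as these compounds go, is whether this amide would behave the same way on the core of compound 1.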